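A few compounds are considered here, and "the series" means these few. Any claim that something is new, unique, unknown or untested is made for them only; others in the source may bear on it.

- compound 1 `CN(C)C(=O)c1cc2cnc(Nc3ccc(NC(=O)C4(C(=O)Nc5ccc(F)cc5)CC4)cc3)nc2n1C1CCCC1` gives 49.8% 
- compound 2 `CN(C)C(=O)c1cc2cnc(Nc3ccc(NC(=O)C4(C(=O)Nc5ccc(F)cc5)CC4)cc3F)nc2n1C1CCCC1` gives 6.2% 

In a functional assay on HeLa cells (Homo sapiens) for inhibition, read by CCK-8 assay, with a stated time of 72 h, tested at 1 uM (on this read-out higher numbers stand for more inhibition of growth at the one concentration tested and lower numbers for less inhibition of growth), compound 1 is the higher of the two measured compounds, at 49.8% and well clear of the other. Compound 3 `CN(C)C(=O)c1cc2cnc(Nc3ccc(NC(=O)C4(C(=O)Nc5ccc(O)cc5)CC4)cc3)nc2n1C1CCCC1` departs from compound 1 by hydroxy in place of fluoro on an aromatic carbon, para to a large group. Going by the values given here, only one measured step exists, a number 43.6 percentage points lower from compound 1 to compound 2 (beyond the scatter), and it comes from fluoro in place of hydrogen on an aromatic carbon elsewhere in the molecule. No measurement covers the present swap, so that step gives no direct size, but its magnitude argues for a wide range. A modest fall in this assay is expected, with the estimated change being a number 13.8 percentage points lower from compound 1 to compound 3 (beyond the scatter). For compound 3 the expected value is 36%, with an estimated range of 12% to 58%.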

Compound 3, percent growth inhibition at one concentration: 62.3%
For compound 3 the middle estimate is 26.3 percentage points below the measured one; the measured number lies above the stated range.
By their numbers in this assay, from the lowest: compound 2; then compound 1; then compound 3.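

Working notes: in this assay, 4-fluorophenyl to 4-hydroxyphenyl gives a number 12.5 percentage points higher from compound 1 to compound 3 (beyond the scatter), so fluoro is not needed at this position for growth inhibition at the one concentration tested, and a hydroxy group is accepted there. Going by these compounds alone, the only earlier step, a number 43.6 percentage points lower from compound 1 to compound 2 (beyond the scatter), came from a fluoro entering elsewhere in the molecule, so the series now holds one change that lowers the number and one, at a different place, that raises it. No measured evidence available here accounts for the rise.

Open, going by these compounds, is whether the rise belongs to the hydroxy group itself or to the loss of fluoro, which the unsubstituted phenyl would help to separate. A methoxy group or an amine at the same place would show how far the change extends beyond hydroxy.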